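The source may hold more compounds than are shown below. What is called first, only, known or untested is meant among the compounds shown, and "the series" means these compounds.

Measured compounds in an assay on cells for displacement of a labelled ligand from D(4) dopamine receptor (Homo sapiens); a higher number here means a weaker inhibitor, a lower number a stronger inhibitor:
compound 1 `COc1cc2c(cc1O)CN(CCCCNC(=O)c1ccc(I)cc1)CC2`: 1500 nM
compound 2 `COc1cc2c(cc1O)CN(CCCCNC(=O)c1ccc(F)cc1)CC2`: 95 nM
compound 3 `COc1cc2c(cc1O)CN(CCCCNC(=O)c1ccc(-c3ccccc3)cc1)CC2`: 720 nM

Compound 1 gives the highest number of the three; its nearest neighbour is compound 3, reached by a 2.1-fold lower number from compound 1 to compound 3 (0.32 log units; beyond the scatter), and its furthest is compound 2, reached by a 16-fold lower number from compound 1 to compound 2 (1.20 log units; beyond the scatter). Both steps lie beyond the scatter.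

Compound 4 `COc1cc2c(cc1O)CN(CCCCNC(=O)c1ccc(Br)cc1)CC2` differs from compound 1 in one place: bromo in place of iodo on an aromatic carbon. Cut one bond further out, the change reads 4-iodophenyl to 4-bromophenyl.

Within the data shown here, two measured steps bear on this. The exchange of iodo for another halogen, fluoro, gave a 16-fold lower number from compound 1 to compound 2 (1.20 log units; beyond the scatter), a large move downward. The exchange of iodo for phenyl gave a 2.1-fold lower number from compound 1 to compound 3 (0.32 log units; beyond the scatter), a modest move in the same direction. Among the measured compounds shown here, every replacement of iodo so far has lowered the number; no measured compound goes against that, but only two replacements are known, and bromo has not yet been tried. For the measured compounds named here, a step downward from compound 1 is therefore expected, most likely smaller than the one to compound 2 and of uncertain size relative to the one to compound 3.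

On that basis compound 4 is expected to give 600 nM in this assay, within 200 nM to 1500 nM, which corresponds to an estimated step of a 2.5-fold lower number from compound 1 to compound 4 (0.40 log units; beyond the scatter).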

Compound 4, inhibition constant: 350 nM
For compound 4 the middle estimate is 1.7-fold (0.23 log units) above the measured one; the measured number falls inside the stated range.
By their numbers in this assay, from the lowest: compound 2; then compound 4; then compound 3; then compound 1.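

In this assay, bromo is the third replacement of iodo at this position to lower the number (a 4.3-fold lower number from compound 1 to compound 4 (0.63 log units; beyond the scatter)), so all three replacements point the same way and no compound shown goes against that. The step in the opposite direction from the fluoro compound (a 3.7-fold higher number from compound 2 to compound 4 (0.57 log units; beyond the scatter)) and the step down from the phenyl compound (a 2.1-fold lower number from compound 3 to compound 4 (0.31 log units; beyond the scatter)) show that the three halogens run fluoro, bromo, iodo from the lowest number to the highest, with phenyl falling between bromo and iodo rather than beyond either end of that order. No measurement at hand offers an explanation for this order.

From the compounds shown here alone, whether chloro would fall between fluoro and bromo, and where hydrogen, methoxy or nitrile would stand relative to these groups at the same position, remains open. Also open, going by these compounds, is whether the same order of fluoro, bromo and iodo would hold with a shorter or longer chain joining the amide to the shared core.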